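Compound 3 to compound 4: a new group on the amine nitrogen

The source may report more compounds than this note shows. Statements on the series, on what has been measured and on what is new or still open speak of the compounds shown alone.

Measured so far in a functional assay on the whole organism with Rattus norvegicus as the target, at a dose of 100 mg/kg; on this read-out lower numbers stand for less inhibition and higher numbers for more inhibition at the one dose given (going by the name of the read-out):
compound 1 `C/N=C(/NC#N)NCCCn1nc(-c2ccccc2)ccc1=O`: 40.5%
compound 2 `CC/N=C(/NC#N)NCCCn1nc(C)ccc1=O`: 34.5%
compound 3 `C/N=C(/NC#N)NCCCn1nc(C)ccc1=O`: 6.8%

Compound 3 stands lowest of the three. Its nearest neighbour is compound 2, the step being a number 27.7 percentage points lower from compound 2 to compound 3 (beyond the scatter); the furthest is compound 1, with a number 33.7 percentage points lower from compound 1 to compound 3 (beyond the scatter). Both steps are beyond the scatter, so the read-out does respond to structure in this series.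

Compound 4 `C/N=C(\S)NCCCn1nc(C)ccc1=O` differs from compound 3 by a group of 4 heavy atoms (2 carbon, 1 nitrogen, 1 sulfur; no ring) in place of a group of 6 heavy atoms (3 carbon, 3 nitrogen; no ring), on an amine nitrogen. Neither measured step bears on this place: one concerns the aromatic carbon, the other the saturated chain carbon bound to a double-bonded nitrogen. There is thus no measured guide to the direction or size of the change in this assay, and the expectation rests on the value of compound 3 alone, with a wide range on the upward side because the two measured changes elsewhere moved the read-out by large and modest amounts.

Compound 4 is expected to give 10%, between 0% and 30%. The expected step of a number 3.2 percentage points higher from compound 3 to compound 4 (within the scatter) is thus not beyond the scatter.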

Compound 4, a percentage reported as inhibition, in the whole organism at one dose (the size of the read-out at that dose, not a potency): -8.2%
Compound 4: middle estimate off by 18.2 percentage points, on the high side; the measured number lies below the stated range.
By their numbers in this assay, from the lowest: compound 4; then compound 3; then compounds 2 and 1 (each within the scatter of the next).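

This position responds in this assay: at the amine nitrogen, putting the group of 4 heavy atoms in place of the group of 6 heavy atoms brings a number 15 percentage points lower from compound 3 to compound 4 (beyond the scatter), so the two groups are not interchangeable here. Compound 4 gives -8.2%, which shows that the read-out in this series can fall below zero and that the low number of compound 3 was not its lowest possible value. No measurement shown here accounts for this step.

On these data alone, it remains open whether the same change on the amine nitrogen has a similar effect on the core of compound 1, which carries phenyl where compound 3 carries methyl. As far as these compounds go, it is also open whether a carbonyl oxygen in place of the sulfur of compound 4, or a longer chain on its double-bonded nitrogen, would shift the number.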